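The source may report more compounds than this note shows. Statements on the series, on what has been measured and on what is new or still open speak of the compounds shown alone.

Compounds measured in a functional assay on SGC-7901 cells (Homo sapiens) for antiproliferative activity, read by MTT assay, with a stated time of 24 h; a lower number here means a stronger inhibitor, a higher number a weaker inhibitor:
- compound 1 `O=c1[nH]cc(S(=O)(=O)Nc2ccccc2-c2cn(-c3ccccc3)nn2)c(=O)[nH]1`: 11800 nM
- compound 2 `O=c1[nH]cc(S(=O)(=O)Nc2ccccc2-c2cn(-c3ccccc3F)nn2)c(=O)[nH]1`: 10800 nM
- compound 3 `O=c1[nH]cc(S(=O)(=O)Nc2ccccc2-c2cn(-c3ccccc3Cl)nn2)c(=O)[nH]1`: 6520 nM

Compound 3 gives the lowest of the three numbers in this assay, but the gaps to its neighbours, a 1.7-fold lower number from compound 2 to compound 3 (0.22 log units; within the scatter) and a 1.8-fold lower number from compound 1 to compound 3 (0.26 log units; within the scatter), are both within the scatter, so no order among the three can be read from them. Compound 4 `O=c1[nH]cc(S(=O)(=O)Nc2ccccc2-c2cn(-c3ccc(Cl)cc3)nn2)c(=O)[nH]1` differs from compound 3 by 4-chlorophenyl in place of 2-chlorophenyl on an aromatic nitrogen. Among the compounds with values here, no measured step moves the chloro to a different place on that ring; the steps that exist, a 1.1-fold lower number from compound 1 to compound 2 (0.04 log units; within the scatter) and a 1.7-fold lower number from compound 2 to compound 3 (0.22 log units; within the scatter), swap what sits at one place and all lie within the scatter. Compound 4 is therefore expected to sit close to compound 3, with an estimated step of a 1.1-fold higher number from compound 3 to compound 4 (0.03 log units; within the scatter). The estimate for compound 4 is 7000 nM, with a range from 3500 nM to 14000 nM.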

Compound 4, half-maximal inhibitory concentration: 2700 nM
Compound 4: middle estimate off by 2.6-fold (0.41 log units), on the high side, outside the stated range (below it).
By their numbers in this assay, from the lowest: compound 4; then compounds 3, 2 and 1 (each within the scatter of the next).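

In this assay, within the data shown here, 4-chlorophenyl in place of 2-chlorophenyl on the aromatic nitrogen gives the first step beyond the scatter (a 2.4-fold lower number from compound 3 to compound 4 (0.38 log units; beyond the scatter)), so the place of the chloro on this ring counts for more here than the swaps among hydrogen, fluoro and chloro did among the earlier compounds. Compound 4 also stands clear of the two remaining compounds (a 4.0-fold lower number from compound 2 to compound 4 (0.60 log units; beyond the scatter); a 4.4-fold lower number from compound 1 to compound 4 (0.64 log units; beyond the scatter)). Nothing available explains this shift. The compounds shown leave open whether 4-fluorophenyl, 4-methoxyphenyl or 4-aminophenyl would behave like 4-chlorophenyl. They also leave open whether a carboxylic acid on that ring would keep this gain.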